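Methyl in Place of Hydrogen on a Phenol Oxygen

The source may report more compounds than this note shows. Statements on the series, on what has been measured and on what is new or still open speak of the compounds shown alone.

Compound 1 `Oc1ccccc1/C=C/c1ccccc1O` gives 24.3 ug/mL in an ADME assay on HEK293 cells (Homo sapiens) for inhibition, read by MTT assay, with a stated time of 2 days; a lower number here means a stronger inhibitor, a higher number a weaker inhibitor.
Compound 2 `Oc1ccc(/C=C/c2ccccc2O)cc1` gives 17.5 ug/mL in this assay.
Compound 3 `Nc1ccccc1/C=C/c1ccc(O)cc1` gives 7 ug/mL in this assay.

Among these three, compound 1 and compound 2 lie within the usual scatter of each other, so the two cannot be ranked. For the measured compounds named here, compound 3 stands apart: the step of a 2.5-fold lower number from compound 2 to compound 3 (0.40 log units; beyond the scatter) is the only measured step that passes the scatter, and the gap between compound 1 and compound 3 is wider still. In short, compound 1 sits at the weak end of what has been measured, together with compound 2.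

Compound 4 `COc1ccccc1/C=C/c1ccccc1O` differs from compound 1 by methyl in place of hydrogen on an oxygen on an aromatic ring. Going by the values given here, no measured step covers this kind of change. Among the compounds with values here, the one step with a number, a 2.5-fold lower number from compound 2 to compound 3 (0.40 log units; beyond the scatter), exchanges one group for another on a ring carbon, while the change to compound 4 keeps the oxygen and adds a methyl to it. With nothing directly comparable, the safest expectation for this assay is a step no larger than the scatter, in either direction. Compound 4 is therefore estimated at 25 ug/mL, with a range from 10 ug/mL to 60 ug/mL, which means an expected step of a 1.0-fold higher number from compound 1 to compound 4 (0.01 log units; within the scatter).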

Compound 4, half-maximal inhibitory concentration: 15 ug/mL
Estimate against measurement, compound 4: 1.7-fold (0.22 log units) above, within the range that was stated.
By their numbers in this assay, from the lowest: compound 3; then compounds 4, 2 and 1 (each within the scatter of the next).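

In this assay, methyl in place of hydrogen on an oxygen on an aromatic ring gives a 1.6-fold lower number from compound 1 to compound 4 (0.21 log units; within the scatter), so compound 1 and compound 4 cannot be ranked, and on this core the hydroxy to methoxy exchange cannot be told apart from repeat-measurement noise. For the compounds shown here, this is the first measured step that keeps the oxygen and changes only what it carries, and it shows that this hydrogen can give way to a methyl without a step that passes the scatter, whereas the exchange of hydroxy for amino on an aromatic carbon gave a 2.5-fold lower number from compound 2 to compound 3 (0.40 log units; beyond the scatter) on a different pair. No measurement shown offers an explanation for this result.

The compounds shown leave open whether a larger group on this oxygen, such as an ethyl or a longer chain, would stay within the scatter as methyl does. They also leave open what an amine in place of the hydroxy would do on the core of compound 1, and whether the remaining hydroxy of compound 4 would accept a methyl in the same way.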